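The source may hold more compounds than are shown below. What is called first, only, known or untested is meant among the compounds shown, and "the series" means these compounds.

Measured compounds:
compound 1 `O/N=C(/Nc1cccc(Br)c1)c1ccc2occc2c1` gives 440 nM
compound 2 `O/N=C(/Nc1cccc(Oc2ccccc2)c1)c1ccc2occc2c1` gives only a limit, > 30000 nM

In an assay on isolated protein for inhibition of Indoleamine 2,3-dioxygenase 1 (Homo sapiens), read by spectrophotometry (a lower number here means a stronger inhibitor, a higher number a weaker inhibitor), compound 1 gives 440 nM. For compound 2 the read-out is only a limit of the assay, > 30000 nM, so its true number is not known. The step of an at least 68-fold higher number from compound 1 to compound 2 (1.83 log units; beyond the scatter) thus carried compound 2 past (the limit of > 30000 nM in this assay, at which 1 of the 2 values shown sits). Compound 3 `O/N=C(/Nc1cccc(COc2ccccc2)c1)c1ccc2occc2c1` differs from compound 2 by phenoxymethyl in place of phenoxy on an aromatic carbon. Among the measured compounds shown here, no measured step shows what this particular change does; the only step at hand, an at least 68-fold higher number from compound 1 to compound 2 (1.83 log units; beyond the scatter), shows that a phenoxy group already takes the number out of the measurable range. With a group of similar kind and size retained, compound 3 is expected to remain weak, most likely again at the limit, so the expected step that the limit leaves unreadable from compound 2 to compound 3 is none beyond the scatter. The estimate for compound 3 is 40000 nM, with a range from 8000 nM to 200000 nM.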

Compound 3, half-maximal inhibitory concentration: > 30000 nM
Compound 3: no number, only a limit; the forecaster's own chance of this, stated with the estimate: 70%; the middle value does not contradict the limit.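

In this assay, compound 3 gives > 30000 nM, which is a limit of the assay and not a number. Phenoxy is therefore not alone in leaving the measurable range at this aromatic carbon, as phenoxymethyl in place of bromo gives an at least 68-fold higher number from compound 1 to compound 3 (1.83 log units; beyond the scatter). The step between compound 2 and compound 3 cannot be read, so nothing shows whether phenoxymethyl differs from phenoxy, and the two compounds simply sit together at the same limit: the limit of > 30000 nM in this assay, at which 2 of the 3 values shown sit.

As far as these compounds go, whether chloro, methoxy or an amine at this place would keep a measurable number remains open. Also open, from the compounds shown here alone, is how far below the limit, if at all, the true numbers of compound 2 and compound 3 lie apart.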